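The compounds below may be only part of what the source reports. "The series", "measured", "known", "first", "only" and "open" are said of these compounds alone.

Compound 3 `CN(C)c1ccc(/C=N/NC(=O)c2cccnc2Nc2cccc(C(F)(F)F)c2)cc1` gives 28.2% in a functional assay on the whole organism (strain Wistar) for inhibition, with Rattus norvegicus as the target, read by paw edema, with a stated time of 4 h, at a dose of 10 mg/kg by the intraperitoneal route (on this read-out higher numbers stand for more inhibition at the one dose given (going by the name of the read-out) and lower numbers for less inhibition), the lowest of the three numbers measured, though compound 1 `O=C(N/N=C/c1ccccc1)c1cccnc1Nc1cccc(C(F)(F)F)c1` with 31% lies within the scatter of it, while compound 2 `COc1ccc(/C=N/NC(=O)c2cccnc2Nc2cccc(C(F)(F)F)c2)cc1OC` at 52.9% stands beyond it. Compound 4 `O=C(N/N=C/c1cccnc1)c1cccnc1Nc1cccc(C(F)(F)F)c1` differs from compound 3 by pyridin-3-yl in place of 4-(dimethylamino)phenyl on a carbon with a double bond to nitrogen. The steps that vary the aryl group at this position are the relevant ones: a number 2.8 percentage points lower from compound 1 to compound 3 (within the scatter) and a number 24.7 percentage points lower from compound 2 to compound 3 (beyond the scatter), the former within the scatter and the latter modest. For the measured compounds named here, no measured step introduces a pyridin-3-yl, so the expectation leans on the phenyl of compound 1. Compound 4 is therefore expected to show a number 2.8 percentage points higher from compound 3 to compound 4 (within the scatter), a change not beyond the scatter. Compound 4 is estimated at 31%, ranging from 16% to 46%.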

Compound 4, a percentage reported as inhibition, in the whole organism at one dose (the size of the read-out at that dose, not a potency): 36%
Beside the measured number, compound 4's estimate is 5 percentage points below it, within the range that was stated.
By their numbers in this assay, from the lowest: compounds 3, 1 and 4 (each within the scatter of the next); then compound 2.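

In this assay pyridin-3-yl on this carbon does not separate from phenyl, with a number 5 percentage points higher from compound 1 to compound 4 (within the scatter), or from 4-(dimethylamino)phenyl, with a number 7.8 percentage points higher from compound 3 to compound 4 (within the scatter). For the compounds shown here, it stays apart from 3,4-dimethoxyphenyl, with a number 16.9 percentage points lower from compound 2 to compound 4 (beyond the scatter), so a ring with a hetero atom does not bring this position level with the one group that stands out. Going by these compounds, whether a single methoxy group on the phenyl, or an amine or a carboxylic acid on it, would reach the number of compound 2 stays open. No evidence at hand explains the gap to 3,4-dimethoxyphenyl.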